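The compounds below may be only part of what the source reports. "The series", "measured", "known", "first", "only" and "open" are said of these compounds alone.

Working notes on the series. Of the compounds shown here, two have numbers so far: compound 1 `O=C(c1ccccc1F)N(/N=N/c1ccc([N+](=O)[O-])cc1Br)c1ccc([N+](=O)[O-])cc1Br` and compound 2 `CC(=O)N(/N=N/c1ccc([N+](=O)[O-])cc1Cl)c1ccc([N+](=O)[O-])cc1Cl`. In a functional assay on HeLa cells (Homo sapiens) for cytotoxicity, read by MTT assay, with a stated time of 72 h (a higher number here means a weaker inhibitor, a lower number a stronger inhibitor), compound 1 gives 1200 nM, and compound 2 gives 630 nM; the two sit within the usual scatter of each other, so neither is set apart. Compound 3 `COC(=O)N(/N=N/c1ccc([N+](=O)[O-])cc1Cl)c1ccc([N+](=O)[O-])cc1Cl` is not yet measured. It differs from compound 2 by methoxy in place of methyl on a carbonyl carbon, that is, acetyl to methoxycarbonyl. Among the compounds with values here, with no measured pair showing what this change does, the step of a 1.1-fold higher number from compound 2 to compound 3 (0.05 log units; within the scatter) is expected to stay within the scatter, with no direction favoured. Compound 3 is therefore estimated at 700 nM, with a range of 300 nM to 1600 nM.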

Compound 3, half-maximal inhibitory concentration: 980 nM
Compound 3: the middle estimate sits 1.4-fold (0.15 log units) below what was measured; the measured number falls inside the stated range.
By their numbers in this assay, from the lowest: compounds 2, 3 and 1 (each within the scatter of the next).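

At this carbonyl carbon, methoxy in place of methyl gives the series its first measured single change: in this assay the step is a 1.6-fold higher number from compound 2 to compound 3 (0.19 log units; within the scatter), so the added oxygen brings no readable shift on the core of compound 2. Nothing measured here accounts for the size of this step. Open, going by these compounds, is whether an amine or a longer chain on this carbonyl carbon would leave the scatter, and whether the same change reads alike on the core of compound 1.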